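The compounds below may be only part of what the source reports. "The series", "measured", "known", "first", "only" and "open" are said of these compounds alone.

Measured so far in a functional assay on WiDr cells (Homo sapiens) for antiproliferative activity, read by sulforhodamine B assay, with a stated time of 48 h; a higher number here means a weaker inhibitor of growth, a lower number a stronger inhibitor of growth:
Compound 1 `CC(C)(C)[Si](C)(C)OC[C@H]1OCCC[C@H]1O[Si](C)(C)C(C)(C)C`: > 100000 nM (a limit)
Compound 2 `CC(C)(C)[Si](C)(C)O[C@@H]1CCCO[C@@H]1CO`: > 100000 nM (a limit)
Compound 3 `CC(C)(C)[Si](C)(C)O[C@@H]1CCCO[C@@H]1/C=C/C(=O)OCc1ccccc1`: 90000 nM

Compound 2 gives only a limit, > 100000 nM. It stands at the limit of > 100000 nM in this assay, at which 2 of the 3 values shown sit, so its true position is not known. The next compound is compound 4 `CC(C)(C)[Si](C)(C)O[C@@H]1CCCO[C@@H]1/C=C\CO`, and the change is 3-hydroxyprop-1-en-1-yl in place of hydroxymethyl on a saturated ring carbon.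

For the measured compounds named here, the one measured step touching compound 2 is a step that the two limits leave unreadable from compound 1 to compound 2. It concerns a different place on the molecule and gives no size to carry over. Going by the values given here, compound 3 also differs from compound 2 at the ring carbon that changes here, and compound 3 gives 90000 nM, the only number. Compound 4 is therefore expected to lie close to compound 3 at 90000 nM, near the top of the range of this assay. Compound 4 may return only a limit.

The expected change is small and towards stronger inhibition of growth, estimated as an at least 1.4-fold lower number from compound 2 to compound 4 (0.15 log units; that floor lies within the scatter). For compound 4 the estimated value is 70000 nM, with an expected range of 25000 nM to 100000 nM.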

Compound 4, concentration for 50% growth inhibition: > 100000 nM
Compound 4 was reported as a limit; the forecaster's own chance of this, stated with the estimate: 50%; at least 1.4-fold (0.15 log units) between middle value and limit.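

In this assay compound 4 gives > 100000 nM, which is a limit and not a number. No step can be read between compound 2 and compound 4, as both stand at the limit: the limit of > 100000 nM in this assay, at which 3 of the 4 values shown sit.

The compounds shown leave open the true positions of compound 2 and compound 4, and whether 3-hydroxyprop-1-en-1-yl in place of hydroxymethyl changes growth inhibition at all.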